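Swapping chloro for cyano on a biaryl amine

This account rests on a few compounds, and the source may have more. Where it says the series, first, only, none or still open, it means among the compounds named here.

Of the compounds shown here, three have so far been tested in a functional assay on Jurkat cells (Homo sapiens) for activation, with a stated time of 24 h; on this read-out lower numbers stand for an effect already at smaller amounts and higher numbers for an effect only at larger amounts of compound. Compound 1, `Oc1ccccc1CNc1ccccc1`, is reported in this assay as "not active" (no number reported). Compound 2, `O=[N+]([O-])c1ccc(NCc2ccccc2O)cc1`, is likewise reported in this assay as "not active" (no number reported). Among the compounds with values here, compound 3, `Oc1ccccc1CNc1ccc(-c2ccc(Cl)cc2)cc1`, is the only one with a measured number: in this assay compound 3 gives 2390 nM. On the numbers shown, compound 3 therefore stands alone; the two other entries carry no number against which it could be placed.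

Compound 4, `N#Cc1ccc(-c2ccc(NCc3ccccc3O)cc2)cc1`, keeps the whole of compound 3 except for one exchange: cyano in place of chloro on an aromatic carbon. In words, this is cyano in place of chloro on an aromatic carbon, at a position para to a large group. Within the data shown here, no step between two measured compounds shows what such an exchange does, so nothing beyond the structures themselves and the single number for compound 3 supports a forecast.

The expected step, a 1.3-fold higher number from compound 3 to compound 4 (0.10 log units; within the scatter), is one that stays within the usual scatter, with no direction claimed. Compound 4 is thus estimated at 3000 nM in this assay, within a range from 800 nM to 12000 nM.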

Compound 4, half-maximal effective concentration: "not active" (no number reported)
Compound 4 has no reported number here; the estimate stays without a comparison.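

Within the data shown here, compound 4 is reported without a number, so the exchange from compound 3 to compound 4 gives no step that can be read. The compounds shown leave open how far cyano in place of chloro moves the number on this read-out. Nothing shown bears on why compound 4 is reported this way.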